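The compounds below may be only part of what the source reports. "The series", "measured", "known", "first", "only" and "open" are said of these compounds alone.

Compound 1 `c1cc(-c2cn[nH]c2)c2c(c1)C(c1ncc[nH]1)CC2` — 84%
Compound 2 `Clc1ccc2c(c1-c1ccn[nH]1)CCC2c1ncc[nH]1` — 40%

Going by the values given here, in a functional assay on CHO cells for agonist activity at Alpha-1A adrenergic receptor (Homo sapiens), read by FLIPR and calcium flux (a lower number here means a smaller maximal response, a higher number a larger maximal response), compound 1 gives 84%, the higher of the two numbers measured so far. Compound 2 gives 40%, a value lower than that of compound 1 by more than the usual scatter. Among the compounds with values here, no pair of measured compounds differs in a single place, so the two values show only that they differ; nothing about any one change can be read from them.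

Compound 3 `c1cc(-c2ncco2)c2c(c1)C(c1ncc[nH]1)CC2` has not been measured in this assay. Its structure differs from compound 1 as follows: 1,3-oxazol-2-yl in place of 1H-pyrazol-4-yl on an aromatic carbon. With no measured step of this kind in the series, the direction of the change is open; a decrease of moderate size in the maximal response is expected, with a wide range around it. Compound 3 is estimated at 65% with a range from 35% to 95%. The expected step is a number 19 percentage points lower from compound 1 to compound 3 (beyond the scatter).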

Compound 3, largest response reached (Emax), in percent of the reference or control that the assay uses: 63%
The estimate for compound 3 lay 2 percentage points above the measured number; the measured number falls inside the stated range.
By their numbers in this assay, from the lowest: compound 2; then compound 3; then compound 1.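

In this assay, going by these compounds alone, replacing 1H-pyrazol-4-yl with 1,3-oxazol-2-yl on an aromatic carbon of the shared core gives the one readable step: a number 21 percentage points lower from compound 1 to compound 3 (beyond the scatter) at this position. The maximal response is therefore sensitive to which five-membered aromatic ring sits here, although compound 3 still reaches 63% in this assay with the oxazole in place. The entering ring has no hydrogen-bond donor and has oxygen in place of one nitrogen, but no available measurement links the step to either difference. On these data alone, it remains open whether the hydrogen-bond donor or the ring atoms account for the step, a question that 1-methyl-1H-pyrazol-4-yl could help separate. Also open, as far as these compounds go, is how far this position tolerates a non-aromatic group such as an amine or a carboxylic acid.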